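This account rests on a few compounds, and the source may have more. Where it says the series, first, only, none or still open, it means among the compounds named here.

- Compound 1 `OC[C@H]1O[C@@H](n2cnc3c(NCc4cccc(F)c4)ncnc32)[C@H](O)[C@@H]1O`: 84000 nM
- Compound 2 `OC[C@H]1O[C@@H](n2cnc3c(NCc4ccc(Cl)cc4)ncnc32)[C@H](O)[C@@H]1O`: > 166000 nM
- Compound 3 `OC[C@H]1O[C@@H](n2cnc3c(NCc4ccc(Br)cc4)ncnc32)[C@H](O)[C@@H]1O`: > 166000 nM

These compounds share one core and differ in the substituted phenyl group, and all were tested in an ADME assay on NIH3T3 cells (Mus musculus) for cytotoxicity, with a stated time of 72 h; a higher number here means a weaker inhibitor, a lower number a stronger inhibitor. Compound 3 gives > 166000 nM, which is a limit of the assay and not a number. The data crowd at the limit of > 166000 nM in this assay, at which 2 of the 3 values shown sit.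

The next compound, compound 4 `Cc1ccc(CNc2ncnc3c2ncn3[C@@H]2O[C@H](CO)[C@@H](O)[C@H]2O)cc1`, carries methyl in place of bromo on an aromatic carbon, para to a large group: methyl in place of bromo on an aromatic carbon.

The nearest measured change is at that same kind of position, with bromo in place of chloro. It gives a step that the two limits leave unreadable from compound 2 to compound 3, so it offers no size to borrow. The two changes away from the 3-fluorophenyl group give an at least 1.9-fold higher number from compound 1 to compound 2 (0.29 log units; that floor lies within the scatter) and an at least 1.9-fold higher number from compound 1 to compound 3 (0.29 log units; that floor lies within the scatter). Both are only floors, and both lie within the scatter.

With so little to go on, no step beyond the scatter is expected in this assay, and no direction can be favoured. Compound 4 may well return only a limit too. The expected outcome is a step that the limit leaves unreadable from compound 3 to compound 4. Compound 4 is estimated at 170000 nM, with an expected range from 80000 nM to 350000 nM.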

Compound 4, half-maximal inhibitory concentration: > 166000 nM
Compound 4 gave a limit, no number; the forecaster's own chance of this, stated with the estimate: 60%; the middle value lies beyond the limit too.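

Methyl on this aromatic carbon, para to a large group, behaves in the same way as chloro and bromo: compound 4 also returns only a limit of the assay, and not a number. The steps among compound 2, compound 3 and compound 4 cannot be read in this assay, because all three sit at the same limit: the limit of > 166000 nM in this assay, at which 3 of the 4 values shown sit. Among the compounds shown here, the one step that can be read is an at least 1.9-fold higher number from compound 1 to compound 4 (0.29 log units; that floor lies within the scatter), and as a floor it does not establish a real difference between the 4-methylphenyl group and the 3-fluorophenyl group.

The compounds shown leave open whether any group at this place, such as an amine, a carboxylic acid or a longer chain, would give a measurable number in this assay. They also leave open how compound 2, compound 3 and compound 4 compare with one another, since the limit hides any differences among them.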